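Replacing the group on the amide of compound 3

The source may report more compounds than this note shows. Statements on the series, on what has been measured and on what is new or still open speak of the compounds shown alone.

compound 1 `CCn1c(C(=O)NCCCN(C)C)ccc1C(CC)(CC)c1ccc(OCCC(O)(CC)CC)c(C)c1` gives 2150 nM
compound 2 `CCn1c(C(=O)NCCN)ccc1C(CC)(CC)c1ccc(OCCC(O)(CC)CC)c(C)c1` gives 2420 nM
compound 3 `CCOC(=O)C(CC(=O)OC)NC(=O)c1ccc(C(CC)(CC)c2ccc(OCCC(O)(CC)CC)c(C)c2)n1CC` gives 5840 nM

All three values come from a functional assay on PC-3 cells (Homo sapiens) for antiproliferative activity, read by MTT assay, with a stated time of 48 h; a higher number here means a weaker inhibitor, a lower number a stronger inhibitor. The compounds keep the shared core and differ in the group on the amide-type nitrogen. The change between the first two gives a 1.1-fold higher number from compound 1 to compound 2 (0.05 log units; within the scatter). Compound 3 has the highest number of the three, and the steps leading to it are a 2.7-fold higher number from compound 1 to compound 3 (0.43 log units; beyond the scatter) and a 2.4-fold higher number from compound 2 to compound 3 (0.38 log units; beyond the scatter).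

The next compound is compound 4 `CCn1c(C(=O)NC(CO)CCO)ccc1C(CC)(CC)c1ccc(OCCC(O)(CC)CC)c(C)c1`, which has not yet been measured. Its difference is a group of 6 heavy atoms (4 carbon, 2 oxygen; no ring) in place of a group of 11 heavy atoms (7 carbon, 4 oxygen; no ring), on an amide-type nitrogen. Going by the values given here, the entering group is 3-hydroxy-1-(hydroxymethyl)propyl, and no measured compound carries it, so no step shows its effect directly. Among the compounds with values here, the only guidance comes from the two modest steps into compound 3, where the group now leaving accompanied the higher number. In this assay, a modest step toward a lower number is therefore expected, though it may not exceed the scatter. The expected step is a 1.7-fold lower number from compound 3 to compound 4 (0.22 log units; within the scatter). For compound 4 the estimated value is 3500 nM, with an expected range from 1500 nM to 8000 nM.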

Compound 4, half-maximal inhibitory concentration: 8760 nM
Beside the measured number, compound 4's estimate is 2.5-fold (0.40 log units) below it; measured number above the stated range.
By their numbers in this assay, from the lowest: compounds 1 and 2 (each within the scatter of the next); then compounds 3 and 4 (each within the scatter of the next).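

In this assay, putting 3-hydroxy-1-(hydroxymethyl)propyl in place of the group of 11 heavy atoms on the amide-type nitrogen gives a 1.5-fold higher number from compound 3 to compound 4 (0.18 log units; within the scatter), so this exchange of one amine-free group for another does not separate the two compounds. The larger contrast lies with the amine-bearing groups: the change from 2-aminoethyl gives a 3.6-fold higher number from compound 2 to compound 4 (0.56 log units; beyond the scatter), and the change from 3-(dimethylamino)propyl gives a 4.1-fold higher number from compound 1 to compound 4 (0.61 log units; beyond the scatter). Among these four compounds the values therefore fall into two sets, with the amine-bearing compound 1 and compound 2 at lower numbers than the amine-free compound 3 and compound 4, and no measurement shown explains that split.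

The compounds shown leave open whether the amine nitrogen itself goes with the lower numbers, and a 2-hydroxyethyl group in place of 2-aminoethyl would test that directly. They also leave open how a carboxylic acid in place of the ester groups of compound 3, or a primary amine on a longer chain than that of compound 2, would read in this assay.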